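The source may report more compounds than this note shows. Statements on the series, on what has been measured and on what is new or still open speak of the compounds shown alone.

Measured compounds:
Compound 1 `O=C(/C=C/c1ccc2c(c1)B(O)OC2)c1ccc(-c2ccccc2)cc1` gives 4900 nM in a functional assay on SK-OV-3 cells (Homo sapiens) for cytotoxicity, read by MTT assay, with a stated time of 48 h; a lower number here means a stronger inhibitor, a higher number a weaker inhibitor.
Compound 2 `Cn1cccc1C(=O)/C=C/c1ccc2c(c1)B(O)OC2` gives 93600 nM in this assay.
Compound 3 `O=C(/C=C/c1ccc2c(c1)B(O)OC2)c1ccc(I)cc1` gives 4200 nM in this assay.

Compound 3 has the lowest of the three numbers, though the nearest step is within the scatter: a 1.2-fold lower number from compound 1 to compound 3 (0.07 log units; within the scatter). The other gap is wide: a 22-fold lower number from compound 2 to compound 3 (1.35 log units; beyond the scatter). Compound 4 `O=C(/C=C/c1ccc2c(c1)B(O)OC2)c1ccc(O)cc1` has not been measured; it differs from compound 3 by hydroxy in place of iodo on an aromatic carbon. Among the compounds with values here, only one measured step touches the same position, the one from compound 1 to compound 3, and it stayed within the scatter. The large step from compound 2 to compound 3 concerns a different part of the molecule and does not speak to a change at this aromatic carbon. Nothing here shows how a hydroxy group at this position behaves. The expectation for compound 4 is therefore a modest step in this assay, leaning toward a higher number, roughly a 1.9-fold higher number from compound 3 to compound 4 (0.28 log units; within the scatter). Compound 4 is estimated at 8000 nM, with a range from 2500 nM to 25000 nM.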

Compound 4, half-maximal inhibitory concentration: 13000 nM
For compound 4 the middle estimate is 1.6-fold (0.21 log units) below the measured one; the range from low to high includes it.
By their numbers in this assay, from the lowest: compounds 3 and 1 (each within the scatter of the next); then compound 4; then compound 2.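

At this aromatic carbon, para to a large group, swapping phenyl for iodo left the number within the scatter, so the position could have seemed tolerant of change. Hydroxy shows that it is not: in this assay there is a 3.1-fold higher number from compound 3 to compound 4 (0.49 log units; beyond the scatter) and a 2.7-fold higher number from compound 1 to compound 4 (0.42 log units; beyond the scatter), so the group here can matter. Even so, the 4-hydroxyphenyl group keeps a clear lead over the 1-methyl-1H-pyrrol-2-yl group on the carbonyl carbon, with a 7.2-fold lower number from compound 2 to compound 4 (0.86 log units; beyond the scatter), and no measurement shown explains either step.

Hydroxy brings a hydrogen-bond donor and iodo none, but this one pair cannot tie the step to that count. From the compounds shown here alone, how an amine or a methoxy group at this carbon would compare remains open.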